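The source may report more compounds than this note shows. Statements on the series, on what has been measured and on what is new or still open speak of the compounds shown alone.

Measured so far:
- Compound 1, `COc1cc2c(cc1OC)CN(S(=O)(=O)c1ccc(-n3cc(COc4ccc([N+](=O)[O-])cc4)nn3)cc1)CC2`: > 50 ug/mL
- Compound 2, `O=Cc1ccc(OCc2cn(-c3ccc(S(=O)(=O)N4CCc5ccccc5C4)cc3)nn2)cc1`: > 50 ug/mL

Both compounds were tested in a functional assay on HuCC-A1 cells (Homo sapiens) for cytotoxicity, read by MTT assay, with a stated time of 48 h; on this read-out lower numbers stand for stronger inhibition and higher numbers for weaker inhibition. In this assay compound 1 gives > 50 ug/mL, which is a limit of the assay and not a measured number. Compound 2 likewise gives > 50 ug/mL, again a limit. So compound 1 cannot be placed above or below anything: the evidence is the limit of > 50 ug/mL in this assay, at which 2 of the 2 values shown sit, and no real number exists for either compound.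

Compound 3, `COc1cc2c(cc1OC)CN(S(=O)(=O)c1ccc(-n3cc(COc4ccccc4)nn3)cc1)CC2`, has not yet been measured. It differs from compound 1 in one place: hydrogen in place of nitro on an aromatic carbon. In words, hydrogen in place of nitro on an aromatic carbon, para to a large group, so the 4-nitrophenoxy end becomes a plain phenoxy end.

Within the data shown here, with no step between measured compounds to lean on, the only guide is that compound 1 sits at the limit. No change beyond the usual scatter is expected from removing the nitro group. Compound 3 is therefore estimated at about 60 ug/mL, with a range from 30 ug/mL to 150 ug/mL. That estimate corresponds to an expected step that the limit leaves unreadable from compound 1 to compound 3, most likely reported again as a limit.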

Compound 3, half-maximal inhibitory concentration: > 50 ug/mL
Compound 3 ended at the assay's limit; the forecaster's own chance of this, stated with the estimate: 80%; the middle value does not contradict the limit.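

In this assay compound 3 gives > 50 ug/mL as a limit of the assay and not a number. Among these compounds, compound 1 also stands at a limit, so no step between compound 1 and compound 3 can be read: the limit of > 50 ug/mL in this assay, at which 3 of the 3 values shown sit.

The compounds shown leave open whether hydrogen in place of nitro changes anything in this assay at all, and what real value any of these compounds has.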